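Dimethylation of the amine on two naphthalene-sulfonamide cores

The source may hold more compounds than are shown below. What is called first, only, known or untested is meant among the compounds shown, and "the series" means these compounds.

Measured so far in an assay on thoracic aorta for binding affinity to Endothelin-1 receptor (Rattus norvegicus); on this read-out higher numbers stand for weaker inhibition and lower numbers for stronger inhibition:
- compound 1, `Cc1noc(NS(=O)(=O)c2cccc3ccc(N)cc23)c1C`: 1450 nM
- compound 2, `Cc1noc(NS(=O)(=O)c2cccc3ccc(N(C)C)cc23)c1C`: 5600 nM
- compound 3, `Cc1noc(NS(=O)(=O)c2ccc3cccc(N)c3c2)c1C`: 9800 nM

Compounds 1 and 3 have the same atoms joined differently; the difference between the two cores is not broken down here. Compound 3 gives the highest of the three numbers, yet against compound 2 it sits within the scatter, so no order between those two is claimed; against compound 1 the gap is beyond the scatter.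

One change has been measured once: dimethylamino in place of amino on an aromatic carbon The step was a 3.9-fold higher number from compound 1 to compound 2 (0.59 log units; beyond the scatter).

Compound 4, `Cc1noc(NS(=O)(=O)c2ccc3cccc(N(C)C)c3c2)c1C`, is not yet measured. It relates to compound 3 as compound 2 relates to compound 1: dimethylamino in place of amino on an aromatic carbon The place differs, though: in the core of compound 1 the carbon is meta to a fused ring and para to a fused ring, in the core of compound 3 it is ortho to a fused ring and meta to a fused ring. This is the same kind of change, not the same one.

For the measured compounds named here, for compound 4 a step of a 3.1-fold higher number from compound 3 to compound 4 (0.49 log units; beyond the scatter) is expected in this assay, resting on the single measured step of the same kind, a 3.9-fold higher number from compound 1 to compound 2 (0.59 log units; beyond the scatter). The place differs, so the range is set wide. The estimated value for compound 4 is 30000 nM, with a range from 9000 nM to 100000 nM.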

Compound 4, half-maximal inhibitory concentration: 31500 nM
Compound 4: the middle estimate sits 1.1-fold (0.02 log units) below what was measured; the measured number falls inside the stated range.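

In this assay, dimethylamino in place of amino on an aromatic carbon, here ortho to a fused ring and meta to a fused ring, again gives a step beyond the scatter: a 3.2-fold higher number from compound 3 to compound 4 (0.51 log units; beyond the scatter). Set beside the earlier step, the change carries from one core to the other with no difference in size that can be resolved: the same change on two cores in this assay, a 3.9-fold higher number (0.59 log units; beyond the scatter) from compound 1 to compound 2 and a 3.2-fold higher number (0.51 log units; beyond the scatter) from compound 3 to compound 4, 1.2-fold (0.08 log units) apart, within the scatter of two such steps This agreement rests on just two pairs in one assay, so it does not show that the step would hold on a further core or at another place on the ring, and it does not show why the number rises.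

The compounds shown leave open whether a single added carbon, as in methylamino, already gives part of this step, or whether the step needs both methyl groups. They also leave open how an acetamide or a pyrrolidine ring in the same place would read on either core.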